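Removing the Chloro from Compound 2: What to Expect

The compounds below may be only part of what the source reports. "The series", "measured", "known", "first", "only" and "open" are said of these compounds alone.

The study measures antiproliferative activity in a functional assay on MOLT-4 cells (Homo sapiens) for antiproliferative activity, read by sulforhodamine B assay, with a stated time of 48 h; on this read-out higher numbers stand for lower toxicity in this test and lower numbers for higher toxicity in this test. Of the compounds shown here, two have been tested. Compound 1 `COc1ccc(OC)c(/C=C/c2nnc(Nc3ccc(Cl)cc3)o2)c1` carries the shared core on an oxadiazole-linked aniline. In this assay compound 1 gives > 100000 nM, which is a limit of the assay rather than a number. Compound 2 `COc1ccc(OC)c(/C=C/C(=O)N/N=C/c2ccc(Cl)cc2)c1` is the open hydrazone analogue bearing the same chloro-substituted ring. In this assay compound 2 gives > 100000 nM, again a limit of the assay and not a measured number. Compound 2 therefore stands at the limit of > 100000 nM in this assay, at which 2 of the 2 values shown sit, so neither tested compound offers a number from which a direction could be read.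

Compound 3 `COc1ccc(OC)c(/C=C/C(=O)N/N=C/c2ccccc2)c1` differs from compound 2 only by hydrogen in place of chloro on an aromatic carbon. Among the measured compounds shown here, no measured step of this kind is available among the tested compounds. Compound 3 is accordingly expected to give 150000 nM, with a range from 50000 nM to 500000 nM. This expectation amounts to a step that the limit leaves unreadable from compound 2 to compound 3, and the most likely outcome is that the assay again reports only a limit.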

Compound 3, concentration lethal to 50% of the cells: > 100000 nM
Compound 3: a limit, no number; the forecaster's own chance of this, stated with the estimate: 80%; the middle value lies beyond the limit too.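

In this assay compound 3 gives > 100000 nM, a limit of the assay and not a number. Compound 2 also stands at a limit, so no step can be read between compound 2 and compound 3: the limit of > 100000 nM in this assay, at which 3 of the 3 values shown sit.

The compounds shown leave open whether going from 4-chlorophenyl to phenyl changes the read-out in this assay at all.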